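Extending the chain while swapping the para substituent

The source may hold more compounds than are shown below. What is called first, only, known or untested is meant among the compounds shown, and "the series" means these compounds.

Compound 3 `CC(C)(C)c1ccc(-c2cc(N3CCC(CCNS(N)(=O)=O)CC3)ncn2)cc1` stands lowest of the three numbers recorded in a functional assay on HT-29 cells (Homo sapiens) for antiproliferative activity, read by sulforhodamine B assay, with a stated time of 48 h (a higher number here means a weaker inhibitor of growth, a lower number a stronger inhibitor of growth), where compound 3 gives 10300 nM. Its nearest neighbour is compound 1 `NS(=O)(=O)NCC1CCN(c2cc(-c3ccc(C(F)(F)F)cc3)ncn2)CC1`, which in this assay gives 29100 nM; furthest is compound 2 `Cc1ccc(-c2cc(N3CCC(CCNS(N)(=O)=O)CC3)ncn2)cc1`, which in this assay gives 52300 nM. Going by the values given here, the one measured step along a single change is a 5.1-fold lower number from compound 2 to compound 3 (0.71 log units; beyond the scatter), a modest but real gain on replacing methyl with tert-butyl on the aromatic carbon.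

Compound 4 `NS(=O)(=O)NCCC1CCN(c2cc(-c3ccc(C(F)(F)F)cc3)ncn2)CC1` differs from compound 3 by trifluoromethyl in place of tert-butyl on an aromatic carbon, the group sitting on an aromatic carbon of a six-membered aromatic ring of carbon only, para to a large group. Among the compounds with values here, no measured step covers tert-butyl against trifluoromethyl directly. Within the data shown here, the only bearing comes from compound 1, which carries trifluoromethyl with a shorter chain and sits between compound 3 and compound 2 in this assay, and from the gain seen in a 5.1-fold lower number from compound 2 to compound 3 (0.71 log units; beyond the scatter), which suggests the tert-butyl group contributes to the standing of compound 3.

Compound 4 is therefore expected to lose some of that standing, with an estimated step of a 1.9-fold higher number from compound 3 to compound 4 (0.29 log units; within the scatter) in this assay. The estimate for compound 4 is 20000 nM, with a range from 8000 nM to 50000 nM.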

Compound 4, concentration for 50% growth inhibition: 22600 nM
Beside the measured number, compound 4's estimate is 1.1-fold (0.05 log units) below it; measured number inside the range.
By their numbers in this assay, from the lowest: compound 3; then compounds 4, 1 and 2 (each within the scatter of the next, the first and the last beyond it).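

At the aromatic carbon para to a large group, three groups can now be compared on the same chain in this assay: trifluoromethyl gives a 2.2-fold higher number from compound 3 to compound 4 (0.34 log units; beyond the scatter) when it replaces tert-butyl, and a 2.3-fold lower number from compound 2 to compound 4 (0.36 log units; beyond the scatter) when it replaces methyl. On this chain the groups therefore rank tert-butyl, trifluoromethyl, methyl from the lowest number to the highest, with both steps beyond the scatter but modest in size. Going by these compounds alone, the chain itself can also be read for the first time, with trifluoromethyl held fixed: a 1.3-fold lower number from compound 1 to compound 4 (0.11 log units; within the scatter) stays within the scatter, so (sulfamoylamino)methyl in place of sulfamoylamino shows no change that can be told apart from repeat variation, and no available data bear on the reason for the ranking of the three groups.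

Within the data shown here, open is whether the chain length is equally silent with tert-butyl on the aromatic ring, since the chain comparison rests on the single trifluoromethyl pair. Also open, as far as these compounds go, is how a chlorine, a methoxy group or a cyclohexyl group at this aromatic carbon, or a longer chain carrying the sulfamoylamino group, would fall against these numbers.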